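One More Methoxy Group on Compound 2

The source may hold more compounds than are shown below. What is called first, only, known or untested is meant among the compounds shown, and "the series" means these compounds.

Compound 1 `CCCn1ccnc1-c1cc(OC)c(OC)c(OC)c1`: > 100000 nM (a limit)
Compound 2 `COc1cccc(-n2ccnc2-c2cc(OC)c(OC)c(OC)c2)c1`: 32200 nM

Going by the values given here, in a functional assay on T47D cells (Homo sapiens) for antiproliferative activity, read by MTT assay, with a stated time of 72 h (on this read-out higher numbers stand for weaker inhibition and lower numbers for stronger inhibition), compound 2 gives 32200 nM, the only actual number so far. The other reading, for compound 1, is a limit: the limit of > 100000 nM in this assay, at which 1 of the 2 values shown sits.

Compound 3 `COc1cc(OC)cc(-n2ccnc2-c2cc(OC)c(OC)c(OC)c2)c1` is compound 2 with a single change, (methoxy in place of hydrogen on an aromatic carbon). In words, it has methoxy in place of hydrogen on an aromatic carbon, meta to a large group and meta to a methoxy group.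

Among the compounds with values here, only one measured step bears on this change, and only loosely. Within the data shown here, that step replaced a whole substituent, and no measured pair shows the addition of a methoxy group directly. Among the measured compounds shown here, with an at least 3.1-fold lower number from compound 1 to compound 2 (0.49 log units; beyond the scatter) as the only guide, a small further move toward lower numbers is expected in this assay, possibly none beyond the scatter.

The expected step is a 1.6-fold lower number from compound 2 to compound 3 (0.21 log units; within the scatter). For compound 3 the estimated value is 20000 nM. The expected range for compound 3 runs from 5000 nM to 80000 nM.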

Compound 3, half-maximal inhibitory concentration: > 100000 nM
Compound 3 ended at the assay's limit; the forecaster's own chance of this, stated with the estimate: 15%; at least 5.0-fold (0.69 log units) between middle value and limit.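

Compound 3 reads > 100000 nM in this assay, and this value is a limit of the assay, not a number. The methoxy group in place of hydrogen on an aromatic carbon, meta to a large group and meta to a methoxy group, therefore gives an at least 3.1-fold higher number from compound 2 to compound 3 (0.49 log units; beyond the scatter), so a change on this ring can also move the read-out toward weaker inhibition, opposite in direction to an at least 3.1-fold lower number from compound 1 to compound 2 (0.49 log units; beyond the scatter). This is the first direct view of a methoxy group added at this position, and it leaves compound 2 as the only compound of the three with an actual number: the limit of > 100000 nM in this assay, at which 2 of the 3 values shown sit.

Going by these compounds alone, since the reading for compound 3 is a limit, the true size of the step stays unknown, and the series offers only one measured number to compare against. Also open, as far as these compounds go, is whether a hydroxyl group, an amine or a fluorine on the same aromatic carbon would shift the read-out in the same direction, and so whether this result belongs to the methoxy group itself or to the position it occupies.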